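The source may report more compounds than this note shows. Statements on the series, on what has been measured and on what is new or still open speak of the compounds shown alone.

Of the compounds shown here, three built on a shared core have been tested in a functional assay on T98G cells (Homo sapiens) for cytotoxicity, read by MTT assay, with a stated time of 48 h; on this read-out higher numbers stand for weaker inhibition and lower numbers for stronger inhibition. Compound 1, with the structure `CC(=NNC(=S)Nc1ccccc1F)c1ccccn1`, gives 3.1 nM. Compound 2, with the structure `CC(=NNC(=S)Nc1ccccc1[N+](=O)[O-])c1ccccn1`, gives 6.6 nM. The change from compound 2 to compound 1 is fluoro in place of nitro on an aromatic carbon, and it produced a 2.1-fold lower number from compound 2 to compound 1 (0.33 log units; beyond the scatter). Compound 3, with the structure `C/C(=N/NC(=S)Nc1ccc([N+](=O)[O-])cc1)c1ccccn1`, gives 140 nM, the highest number of the three; the difference between the cores of compound 3 and compound 2 is not broken down here. Compound 4, with the structure `C/C(=N/NC(=S)Nc1ccc(F)cc1)c1ccccn1`, has not yet been measured in this assay. The change from compound 3 to compound 4 is fluoro in place of nitro on an aromatic carbon, the same kind of change as that from compound 2 to compound 1, but the group now sits para to a large group rather than ortho to it. A modest step is expected, a 2.5-fold lower number from compound 3 to compound 4 (0.41 log units; beyond the scatter), because the earlier change gave a 2.1-fold lower number from compound 2 to compound 1 (0.33 log units; beyond the scatter). Compound 4 is thus expected to give about 55 nM, likely between 15 nM and 200 nM.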

Compound 4, half-maximal inhibitory concentration: 17 nM
Estimate against measurement, compound 4: 3.2-fold (0.51 log units) above; low and high end bracket the measured number.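

In this assay, putting fluoro in place of nitro gives an 8.2-fold lower number from compound 3 to compound 4 (0.92 log units; beyond the scatter). The number falls on both cores, but the size of the step does not carry over from one core to the other: the same change on two cores in this assay, a 2.1-fold lower number (0.33 log units; beyond the scatter) from compound 2 to compound 1 and an 8.2-fold lower number (0.92 log units; beyond the scatter) from compound 3 to compound 4, 3.9-fold (0.59 log units) apart, beyond the scatter of two such steps So the earlier step gave the direction here but was a poor guide to the size. These two pairs cannot show why the steps differ, since the group sits para to a large group in compound 3 and compound 4, and nothing shown separates that placement from other differences between the cores.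

The compounds shown carry only fluoro or nitro at the changing place, so it remains open how an amine, a carboxylic acid or a longer chain would behave there. As far as these compounds go, it also remains open whether a fluoro-for-nitro step on any further core would land nearer the smaller or the larger of these two steps.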